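Cytotoxicity limits across a biaryl amide series

A few compounds are considered here, and "the series" means these few. Any claim that something is new, unique, unknown or untested is made for them only; others in the source may bear on it.

Measured so far in an ADME assay on HepG2 cells (Homo sapiens) for cytotoxicity, read by CellTiter-Glo and resazurin assay, with a stated time of 72 h; a lower number here means that less compound is needed, a higher number that more compound is needed for the effect:
compound 1 `COc1cc(OC)cc(-c2ccc(C(=O)N(Cc3cccc(OCCCCCC(=O)O)c3)C(C)C)cc2)c1` gives > 26000 nM, a limit of the assay.
compound 2 `CC(C)N(Cc1cccc(OCCCCCC(=O)O)c1)C(=O)c1ccc(-c2cccc(OC(F)(F)F)c2)cc1` gives > 26000 nM, a limit of the assay.

Compound 2 thus stands only at the limit, where both values sit (the limit of > 26000 nM in this assay, at which 2 of the 2 values shown sit). Among the measured compounds shown here, the one change within the measured set, a step that the two limits leave unreadable from compound 1 to compound 2, cannot be sized. Compound 3 `COc1cc(F)cc(-c2ccc(C(=O)N(Cc3cccc(OCCCCCC(=O)O)c3)C(C)C)cc2)c1` differs from compound 2 by 3-fluoro-5-methoxyphenyl in place of 3-(trifluoromethoxy)phenyl on an aromatic carbon. No readable step bears on this change, and the two limits give no direction. Compound 3 is expected to show 30000 nM (range 15000 nM to 100000 nM) in this assay, most likely again reported only as a limit. The expected step that the limit leaves unreadable from compound 2 to compound 3 is accordingly none beyond the scatter.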

Compound 3, half-maximal effective concentration: > 26000 nM
Compound 3 ended at the assay's limit (the forecaster's own chance of this, stated with the estimate: 85%); the middle value is on the limit's open side.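

Among the compounds shown here, no step among compound 1, compound 2 and compound 3 can be read in this assay, each value being a limit of the assay: the limit of > 26000 nM in this assay, at which 3 of the 3 values shown sit. From the compounds shown here alone, how far these compounds lie beyond that limit, and whether the ring substituents matter, stays open.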